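Cytotoxicity notes on an amide-imide series

This account rests on a few compounds, and the source may have more. Where it says the series, first, only, none or still open, it means among the compounds named here.

In an ADME assay on SW480 cells (Homo sapiens) for cytotoxicity, read by MTT assay, with a stated time of 72 h (on this read-out lower numbers stand for stronger inhibition and higher numbers for weaker inhibition), compound 1 `CCCCCN1C(=O)C/C(=C\c2cccc(C(=O)NCCCC)c2)C1=O` reaches only the limit > 100000 nM. Compound 2 `Cc1ccc(NC(=O)c2cccc(/C=C3\CC(=O)N(c4ccccc4)C3=O)c2)cc1C` likewise reaches only the limit > 100000 nM. Compound 3 `COc1ccc(NC(=O)c2cccc(CC3CC(=O)N(c4ccc(C)cc4)C3=O)c2)cc1` also stops at the limit, > 100000 nM. Compound 2 therefore stands where every value shown stands, (the limit of > 100000 nM in this assay, at which 3 of the 3 values shown sit), and no number is available to rank it against the others. Compound 4 `O=C(NCc1ccccc1)c1cccc(/C=C2\CC(=O)N(c3ccccc3)C2=O)c1` carries benzyl in place of 3,4-dimethylphenyl on an amide-type nitrogen, the remainder of the core of compound 2 being kept. Among the compounds with values here, no step between measured compounds exists to size this change; with all three values at the limit, no movement beyond the scatter is expected in either direction. The expected step is a step that the limit leaves unreadable from compound 2 to compound 4. Compound 4 is expected to give 120000 nM (range 50000 nM to 300000 nM), most probably again reported as a limit.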

Compound 4, half-maximal inhibitory concentration: > 100000 nM
Compound 4: a limit, no number; the forecaster's own chance of this, stated with the estimate: 85%; the middle value is on the limit's open side.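

No step can be read from compound 2 to compound 4, as both values are limits: the limit of > 100000 nM in this assay, at which 4 of the 4 values shown sit. The compounds shown leave open whether any change to the shared core would give a numerical value on this read-out.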